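The compounds below may be only part of what the source reports. "The series", "measured", "known", "first", "only" and "open" are said of these compounds alone.

- compound 1 `O=C1COc2ccccc2N1CCCn1cc(-c2ccccc2)nn1`: 370 nM
- compound 2 `Cc1ccc(-c2cn(CCCN3C(=O)COc4ccccc43)nn2)cc1`: 4400 nM

In a functional assay on IMR-32 cells (Homo sapiens) for antiproliferative activity, read by sulforhodamine B assay, with a stated time of 48 h (a higher number here means a weaker inhibitor of growth, a lower number a stronger inhibitor of growth), compound 2 has the higher of the two numbers, 4400 nM, making it the weaker growth inhibitor. Compound 3 `CCCCCc1ccc(-c2cn(CCCN3C(=O)COc4ccccc43)nn2)cc1` has butyl in place of hydrogen on a saturated chain carbon bound to an aromatic carbon, so methyl becomes pentyl: butyl in place of hydrogen on a saturated chain carbon bound to an aromatic carbon. Within the data shown here, only one measured step bears on this: a 12-fold higher number from compound 1 to compound 2 (1.08 log units; beyond the scatter). That large step added methyl on an aromatic carbon, and no longer chain has been measured, so it is a weak guide. A small further rise is expected, though a change in either direction remains possible. The expected step is a 1.1-fold higher number from compound 2 to compound 3 (0.06 log units; within the scatter). For compound 3, the estimate is 5000 nM, with an expected range of 1000 nM to 25000 nM.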

Compound 3, concentration for 50% growth inhibition: 43500 nM
For compound 3 the middle estimate is 8.7-fold (0.94 log units) below the measured one, outside the stated range (above it).
By their numbers in this assay, from the lowest: compound 1; then compound 2; then compound 3.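

Lengthening methyl to pentyl in this assay gives a 9.9-fold higher number from compound 2 to compound 3 (1.00 log units; beyond the scatter) and shows that the loss seen with methyl continues with a longer chain at this position. Pentyl in place of the original hydrogen gives a 120-fold higher number from compound 1 to compound 3 (2.07 log units; beyond the scatter) and leaves the hydrogen compound ahead, with none of the three compounds going against this order. No measurement here explains the loss.

From the compounds shown here alone, whether an ethyl or propyl chain falls between these values remains open, as does whether a hydroxyl or an amine on the chain would restore growth inhibition.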